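A Fluorophenoxy Arm in Place of Methylpiperazine

The source may hold more compounds than are shown below. What is called first, only, known or untested is meant among the compounds shown, and "the series" means these compounds.

Three compounds built on one shared core were examined in a functional assay on SUP-B15 cells (Homo sapiens) for antiproliferative activity, with a stated time of 72 h; a lower number here means that less compound is needed, a higher number that more compound is needed for the effect. Compound 1 `COc1ccc(-c2cc(=O)c3c(OC)cc(OC)cc3n2Cc2ccccc2)cc1` gave only a limit of the assay, > 34400 nM. Compound 2 `COc1cc(OC)c2c(=O)cc(C(=O)Nc3ccc(C4CCCCC4)cc3)[nH]c2c1` likewise reached only a limit, > 43100 nM. Compound 3 `COc1cc(OC)c2c(=O)cc(C(=O)Nc3ccc(N4CCN(C)CC4)cc3)[nH]c2c1` also stopped at a limit, > 19800 nM. Within the data shown here, the one single change among the measured compounds, a step that the two limits leave unreadable from compound 2 to compound 3, cannot be read, because both of its ends are limits. Compound 3 therefore stands on a limit, and the two other values shown are limits as well: the limit of > 19800 nM in this assay, at which 1 of the 3 values shown sits, the limit of > 34400 nM in this assay, at which 1 of the 3 values shown sits, and the limit of > 43100 nM in this assay, at which 1 of the 3 values shown sits, together say that none of the three reached a measurable effect.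

Compound 4 `COc1cc(OC)c2c(=O)cc(C(=O)Nc3ccc(Oc4ccc(F)cc4)cc3)[nH]c2c1` differs from compound 3 in one place: 4-fluorophenoxy in place of 4-methylpiperazin-1-yl on an aromatic carbon. Among the measured compounds shown here, no measured step bears on this change in a readable way, since every step available is hidden behind limits, so no direction and no size can be drawn from them. The plain expectation is that compound 4 behaves as its three relatives did. Compound 4 is expected at about 40000 nM, within a range from 12000 nM to 130000 nM, most likely again reported only as a limit. This estimate amounts to an expected step that the limit leaves unreadable from compound 3 to compound 4, not beyond the scatter.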

Compound 4, half-maximal effective concentration: > 50000 nM
Compound 4: no number, only a limit; the forecaster's own chance of this, stated with the estimate: 70%; middle value at least 1.2-fold (0.09 log units) from the limit.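

Compound 4 gives > 50000 nM, which is again only a limit of the assay. Among these compounds, the steps to compound 4 from compound 2 and from compound 3 therefore cannot be read, and no new step emerges. The compounds shown leave open whether any change to this shared core can produce a measurable effect in this assay.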